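Swapping Chloro for Fluoro on the Benzyl Group

The compounds below may be only part of what the source reports. "The series", "measured", "known", "first", "only" and "open" are said of these compounds alone.

Three measured compounds share one core and differ only in the group on the pendant phenyl ring. In an assay for inhibition of MAP kinase-interacting serine/threonine-protein kinase 2 (Homo sapiens), read by luminescence and ADP-Glo, with a stated time of 2 h (on this read-out higher numbers stand for weaker inhibition and lower numbers for stronger inhibition), compound 1 `NC(=O)c1cccc(Cn2cc(-c3ccc4cn[nH]c4c3)ccc2=O)c1` gives 106 nM, compound 2 `Nc1cccc(Cn2cc(-c3ccc4cn[nH]c4c3)ccc2=O)c1` gives 84 nM, and compound 3 `O=c1ccc(-c2ccc3cn[nH]c3c2)cn1Cc1cccc(Cl)c1` gives 40 nM, the lowest of the three, with both other numbers standing beyond the scatter above it. Compound 4 `O=c1ccc(-c2ccc3cn[nH]c3c2)cn1Cc1cccc(F)c1` differs from compound 3 by fluoro in place of chloro on an aromatic carbon. For the measured compounds named here, no measured pair exchanges one halogen for another; the steps that touch this position are a 2.7-fold lower number from compound 1 to compound 3 (0.42 log units; beyond the scatter) and a 2.1-fold lower number from compound 2 to compound 3 (0.32 log units; beyond the scatter), both modest. Fluoro keeps a halogen in that place, so for compound 4 the expected step is a 1.5-fold higher number from compound 3 to compound 4 (0.18 log units; within the scatter), a small rise likely within the scatter. Compound 4 is estimated at 60 nM, between 25 nM and 150 nM.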

Compound 4, half-maximal inhibitory concentration: 38 nM
For compound 4 the middle estimate is 1.6-fold (0.20 log units) above the measured one; measured number inside the range.
By their numbers in this assay, from the lowest: compounds 4 and 3 (each within the scatter of the next); then compounds 2 and 1 (each within the scatter of the next).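

In this assay, for the compounds shown here, the first exchange of one halogen for another at this position gives a 1.1-fold lower number from compound 3 to compound 4 (0.02 log units; within the scatter), so chloro and fluoro cannot be told apart here. Fluoro also stands clear of the other two groups, with a 2.2-fold lower number from compound 2 to compound 4 (0.34 log units; beyond the scatter) and a 2.8-fold lower number from compound 1 to compound 4 (0.45 log units; beyond the scatter), which extends the gap seen with chloro to a second halogen. No evidence available here accounts for these numbers.

The compounds shown leave open how bromo, methoxy or a carboxylic acid would read in this place. They also leave open whether fluoro would match these numbers on another carbon of the phenyl ring.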